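The source may hold more compounds than are shown below. What is called first, only, known or untested is meant among the compounds shown, and "the series" means these compounds.

Measured so far, in a functional assay on BXPC-3 cells (Homo sapiens) for inhibition, read by MTT assay, with a stated time of 7 days; on this read-out higher numbers stand for weaker inhibition and lower numbers for stronger inhibition:

- compound 1 `CCN(CC)S(=O)(=O)c1ccc(S(=O)(=O)N2CCC[C@@H](C(=O)NC)C2)cc1` gives 13800 nM
- compound 2 `CCN(CC)S(=O)(=O)c1ccc(S(=O)(=O)N2CCC[C@@H](C(=O)NC3CN(C(=O)OC(C)(C)C)C3)C2)cc1` gives 1800 nM
- compound 3 `CCN(CC)S(=O)(=O)c1ccc(S(=O)(=O)N2CCC[C@@H](C(=O)NC3CN(S(C)(=O)=O)C3)C2)cc1` gives 7400 nM

All three share one core and differ only in the group carried on the amide nitrogen. Compound 3 stands second highest of the three numbers: its nearest neighbour is compound 1, within the scatter, while compound 2 lies clearly lower.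

The next compound, compound 4 `CCN(CC)S(=O)(=O)c1ccc(S(=O)(=O)N2CCC[C@@H](C(=O)N[C@H]3CCN(C(=O)OC(C)(C)C)C3)C2)cc1`, is made from compound 3 by a change in one place: 1-(tert-butoxycarbonyl)pyrrolidin-3-yl in place of 1-(methylsulfonyl)azetidin-3-yl on an amide-type nitrogen. Among the compounds with values here, two measured steps bear on this. The step of a 4.1-fold higher number from compound 2 to compound 3 (0.61 log units; beyond the scatter) shows what the swap between the tert-butoxycarbonyl cap and the methylsulfonyl cap did on the azetidine ring; going the other way, as here, should therefore lower the number. The step of a 7.7-fold lower number from compound 1 to compound 2 (0.88 log units; beyond the scatter) shows that the tert-butoxycarbonyl-capped ring is the most favourable group seen so far. Within the data shown here, what no measured step covers is the move from a four-membered ring to a five-membered one, so that part of the change is uncertain.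

On this basis compound 4 is expected to land near compound 2, with a step of a 3.4-fold lower number from compound 3 to compound 4 (0.53 log units; beyond the scatter). The estimate for compound 4 in this assay is 2200 nM, with a range from 700 nM to 7000 nM.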

Compound 4, half-maximal inhibitory concentration: 300 nM
Compound 4: the middle estimate sits 7.3-fold (0.87 log units) above what was measured; the whole stated range lies above it.
By their numbers in this assay, from the lowest: compound 4; then compound 2; then compounds 3 and 1 (each within the scatter of the next).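

In this assay, keeping the tert-butoxycarbonyl cap and replacing the four-membered ring with the five-membered one gives a 6.0-fold lower number from compound 2 to compound 4 (0.78 log units; beyond the scatter), so the ring itself, and not only its cap, affects the number at this amide-type nitrogen. The earlier compounds shown here could not show this, since both capped groups among them were built on the four-membered ring. The full change, with ring and cap swapped together, gives a 25-fold lower number from compound 3 to compound 4 (1.39 log units; beyond the scatter), and measured against the plain methyl group it gives a 46-fold lower number from compound 1 to compound 4 (1.66 log units; beyond the scatter), which makes compound 4 the most potent of the four in this assay, although no evidence here explains why this group does so much better.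

The compounds shown leave open how much of the gain comes from ring size and how much from the defined stereocentre that enters with the five-membered ring, and how the methylsulfonyl cap would behave on that ring. They also leave open what a free amine or an acetyl group in place of the tert-butoxycarbonyl cap would give there.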